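The source may hold more compounds than are shown below. What is called first, only, known or untested is meant among the compounds shown, and "the series" means these compounds.

Measured so far:
compound 1, `CCNc1nc(C)nc(O)c1C#N`, gives 2600 nM in a functional assay (muscle tissue) with Felis catus as the target; a lower number here means that less compound is needed, a higher number that more compound is needed for the effect
compound 2, `CCc1nc(O)c(C#N)c(NCc2cccnc2)n1`, gives 5500 nM in this assay

Compound 2 holds the highest of the two numbers shown in this assay; its only neighbour is compound 1, whose lower number stands at a gap beyond the usual scatter. Among the compounds with values here, no single-point step between the two measured compounds can be drawn, since they differ in more than one place, so what they show is only that compound 1 needs less compound than compound 2 for the effect.

Compound 3, `CC(C)c1nc(O)c(C#N)c(NCc2cccnc2)n1`, is not yet measured. It differs from compound 2 by methyl in place of hydrogen on a saturated chain carbon bound to an aromatic carbon and a saturated chain carbon.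

Within the data shown here, with no measured step of this kind to lean on, the expected change is small: the step from compound 2 to compound 3 in this assay is estimated as a 1.1-fold lower number from compound 2 to compound 3 (0.04 log units; within the scatter), in either direction no further than the scatter allows. On that basis compound 3 is expected to give about 5000 nM in this assay, with a plausible range from 2000 nM to 14000 nM.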

Compound 3, half-maximal effective concentration: 33000 nM
Estimate against measurement, compound 3: 6.6-fold (0.82 log units) below; measured number outside the range, above it.
By their numbers in this assay, from the lowest: compound 1; then compound 2; then compound 3.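

Within the data shown here, the first single-point step falls on a saturated chain carbon bound to an aromatic carbon and a saturated chain carbon: ethyl to isopropyl gives a 6.0-fold higher number from compound 2 to compound 3 (0.78 log units; beyond the scatter) in this assay. This shows that the position is sensitive to the change, since a single added methyl, with no ring, no hydrogen-bond donor or acceptor and no net charge, moves the number beyond the scatter and towards more compound needed for the effect. Nothing at hand accounts for the size of this step.

Still open, on these data alone, is whether a straight propyl chain at this position would read like ethyl or like isopropyl, and whether a tert-butyl group would carry the step further, which would separate the effect of branching from that of chain length. Also open, as far as these compounds go, is whether the same ethyl to isopropyl step would hold with the ethylamino group of compound 1 on the shared core, as this single pair speaks for one amine substituent only.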